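Compound 3 to compound 4: methoxy in place of chloro

The source may report more compounds than this note shows. Statements on the series, on what has been measured and on what is new or still open speak of the compounds shown alone.

In a functional assay on MCF7 cells (Homo sapiens) for antiproliferative activity, read by MTT assay, with a stated time of 48 h (a lower number here means a stronger inhibitor, a higher number a weaker inhibitor), compound 1 (`COc1ccc2[nH]c(-c3cn(-c4ccccc4)nc3-c3ccc(Cl)cc3)nc2c1`) gives 1760 nM and compound 2 (`COc1ccc(-c2nn(-c3ccccc3)cc2-c2nc3cc(F)ccc3[nH]2)cc1`) gives 1510 nM. Compound 3 (`COc1ccc(-c2nn(-c3ccccc3)cc2-c2nc3cc(Cl)ccc3[nH]2)cc1`) gives 1760 nM, level with compound 1 and within the scatter of compound 2, so these values set no order. Compound 4 (`COc1ccc(-c2nn(-c3ccccc3)cc2-c2nc3cc(OC)ccc3[nH]2)cc1`) carries methoxy in place of chloro on an aromatic carbon. For the measured compounds named here, the one measured step at this carbon, chloro in place of fluoro, is small: a 1.2-fold higher number from compound 2 to compound 3 (0.07 log units; within the scatter). On that single step, no change beyond the scatter is expected in this assay. The estimated step is a 1.0-fold lower number from compound 3 to compound 4 (0.02 log units; within the scatter). For compound 4 the expected value is 1700 nM, with an estimated range of 900 nM to 3200 nM.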

Compound 4, half-maximal inhibitory concentration: 3130 nM
Compound 4: middle estimate off by 1.8-fold (0.27 log units), on the low side; the range from low to high includes it.
By their numbers in this assay, from the lowest: compounds 2, 1, 3 and 4 (each within the scatter of the next, the first and the last beyond it).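

In this assay this aromatic carbon now shows its first step beyond the scatter, modest in size, with methoxy in place of fluoro (a 2.1-fold higher number from compound 2 to compound 4 (0.32 log units; beyond the scatter)). Methoxy in place of chloro stays within the scatter, both at this carbon (a 1.8-fold higher number from compound 3 to compound 4 (0.25 log units; within the scatter)) and at a different aromatic carbon (a 1.8-fold higher number from compound 1 to compound 4 (0.25 log units; within the scatter)). No measurement at hand offers an explanation for these steps.

Still open, as far as these compounds go, is how an amine or a carboxylic acid at this carbon would compare with fluoro, chloro and methoxy. Also open is whether a plain hydrogen there would give a number outside the scatter of these compounds.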